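The source may hold more compounds than are shown below. What is called first, only, known or untested is meant among the compounds shown, and "the series" means these compounds.

Measured compounds:
- Compound 1, `COc1cc(C(C2=C(O)C(=O)c3ccccc3C2=O)c2c[nH]c3ccc(Br)cc23)cc(OC)c1OC`, gives 36300 nM in a toxicity assay (Homo sapiens) for cytotoxicity, read by MTT assay, with a stated time of 48 h; a higher number here means a weaker inhibitor, a lower number a stronger inhibitor.
- Compound 2, `COc1cccc(C(C2=C(O)C(=O)c3ccccc3C2=O)c2c[nH]c3ccccc23)c1`, gives 110000 nM in this assay.

Compound 1 holds the lower of the two values shown; compound 2 sits at a higher number, and that gap lies beyond the scatter. Among the compounds with values here, the two compounds differ in more than one place, so the pair supports no single step and no direction for any one change.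

Compound 3, `O=C1C(O)=C(C(c2ccc([N+](=O)[O-])cc2)c2c[nH]c3ccc(Br)cc23)C(=O)c2ccccc21`, is not yet measured. Relative to compound 1 the change is 4-nitrophenyl in place of 3,4,5-trimethoxyphenyl on a saturated chain carbon bound to an aromatic carbon and a double-bonded ring carbon. Within the data shown here, no measured pair isolates an exchange of the aryl group at that position, so the direction of the step in this assay cannot be read from the series; the expectation is a step within or only modestly beyond the scatter, with no clear sign. The expected step is a 1.1-fold higher number from compound 1 to compound 3 (0.04 log units; within the scatter). Compound 3 is therefore estimated at 40000 nM, with a range from 12000 nM to 130000 nM.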

Compound 3, half-maximal inhibitory concentration: 45200 nM
Compound 3: the middle estimate sits 1.1-fold (0.05 log units) below what was measured; low and high end bracket the measured number.
By their numbers in this assay, from the lowest: compounds 1 and 3 (each within the scatter of the next); then compound 2.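

In this assay, the position on a saturated chain carbon bound to an aromatic carbon and a double-bonded ring carbon now has its first single-place step: 4-nitrophenyl in place of 3,4,5-trimethoxyphenyl gives a 1.2-fold higher number from compound 1 to compound 3 (0.10 log units; within the scatter), so this exchange does not separate the two compounds. At this position, 12 heavy atoms and 3 hydrogen-bond acceptors leave and 9 heavy atoms and 2 hydrogen-bond acceptors enter, with the six-membered aromatic ring of carbon kept, and the reading stays within the scatter. No measurement at hand explains this outcome.

On these data alone, whether a group without that aromatic ring, such as an amine or a carboxylic acid, would produce a step beyond the scatter at this position remains open. Compound 2 differs from compound 1 and from compound 3 in more than one place, so the contribution of the bromine also remains unresolved.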